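Tert-butoxycarbonyl in place of cyclobutylcarbonyl on an inactive series

The source may hold more compounds than are shown below. What is called first, only, known or untested is meant among the compounds shown, and "the series" means these compounds.

The series is measured in an assay on Sf9 cells for inhibition of inhibitor of nuclear factor kappa-B kinase subunit epsilon (Homo sapiens), read by ADP-Glo, with a stated time of 60 min; a lower number here means a stronger inhibitor, a higher number a weaker inhibitor. Compound 1 `Cc1[nH]nc(N)c1-c1cccc(C(F)(F)F)c1` gives only a limit of the assay, > 100000 nM, in this assay. Compound 2 `Cc1nn(C(=O)C2CC2)c(N)c1-c1ccc(Cl)c(Cl)c1` likewise gives a limit, > 100000 nM. Compound 3 `Cc1nn(C(=O)C2CCC2)c(N)c1-c1ccc(Cl)c(Cl)c1` also stands at a limit, > 100000 nM, so its place on the numbers shown is known only as a limit and not as a number. The step that the two limits leave unreadable from compound 2 to compound 3 is therefore not readable, and all three values shown sit at the same limit (the limit of > 100000 nM in this assay, at which 3 of the 3 values shown sit).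

Compound 4 `Cc1nn(C(=O)OC(C)(C)C)c(N)c1-c1ccc(Cl)c(Cl)c1` differs from compound 3 by tert-butoxy in place of cyclobutyl on a carbonyl carbon. Among the measured compounds shown here, no measured step bears on this exchange, since the one change measured left both ends at a limit. For the measured compounds named here, the only evidence is that every value shown sits at the limit (the limit of > 100000 nM in this assay, at which 3 of the 3 values shown sit), so no step beyond the scatter is expected in this assay in either direction. Compound 4 is therefore expected to remain at the limit, with an estimate of 150000 nM (40000 nM to 600000 nM), and the step that the limit leaves unreadable from compound 3 to compound 4 is expected to be essentially none.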

Compound 4, half-maximal inhibitory concentration: > 100000 nM
Compound 4 ended at the assay's limit; the forecaster's own chance of this, stated with the estimate: 85%; the middle value does not contradict the limit.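

The steps from compound 2 and from compound 3 to compound 4 cannot be read, as all three compounds stand at a limit: the limit of > 100000 nM in this assay, at which 4 of the 4 values shown sit.

The compounds shown leave open whether any change to the shared core would give a measurable value in this assay.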